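Halogen swap on the fused ring of compound 3

The source may report more compounds than this note shows. Statements on the series, on what has been measured and on what is new or still open speak of the compounds shown alone.

The series shares one core and varies the substituent on the fused two-ring system. Compound 1 `CS(=O)(=O)c1ccc(Nc2ncc(F)c(Nc3nc4ccccc4s3)n2)cc1` carries hydrogen at that site; in a functional assay on PC-3 cells (Homo sapiens) for antiproliferative activity, read by MTT assay, with a stated time of 48 h (on this read-out higher numbers stand for weaker inhibition and lower numbers for stronger inhibition), compound 1 gives 2830 nM. Compound 3 `CS(=O)(=O)c1ccc(Nc2ncc(F)c(Nc3nc4ccc(Cl)cc4s3)n2)cc1` carries chloro there, and in this assay compound 3 gives only a limit of the assay, > 50000 nM. Among the measured compounds shown here, the step of an at least 17-fold higher number from compound 1 to compound 3 (1.24 log units; beyond the scatter) is the one measured change at this position, and it is large. Compound 2 `Cc1cnc(Nc2ccc(S(C)(=O)=O)cc2)nc1Nc1nc2ccc(F)cc2s1` also reaches only a limit, > 50000 nM, in this assay. Compound 2 differs from compound 4 in a second place, so its value stands on its own. Most values sit at the limit of > 50000 nM in this assay, at which 2 of the 3 values shown sit, so compound 3 stands at the weak end of the numbers shown, together with compound 2.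

Compound 4 `CS(=O)(=O)c1ccc(Nc2ncc(F)c(Nc3nc4ccc(F)cc4s3)n2)cc1` is the next step: fluoro in place of chloro on an aromatic carbon. For the measured compounds named here, only the step from compound 1 to compound 3 bears on it, and that step moved the number well beyond the scatter; whether fluoro lands nearer hydrogen or nearer chloro cannot be read from it. Compound 2, with the same fluoro on the fused ring, gives a limit. Compound 4 is therefore expected to give about 25000 nM, ranging from 5000 nM to 100000 nM. The expected step is an at least 2.0-fold lower number from compound 3 to compound 4 (0.30 log units; that floor lies within the scatter), with a fair chance that only a limit is again reported.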

Compound 4, half-maximal inhibitory concentration: > 50000 nM
Compound 4: only a limit was reported; the forecaster's own chance of this, stated with the estimate: 45%; middle value at least 2.0-fold (0.30 log units) away from the limit.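

Fluoro on the fused ring does not restore the hydrogen result in this assay: the hydrogen-to-fluoro change gives an at least 17-fold higher number from compound 1 to compound 4 (1.24 log units; beyond the scatter). The large rise seen with chloro is therefore not confined to chloro, and among the three groups shown at this site, hydrogen alone gives a number that can be read as a value. The steps from compound 3 to compound 4 and from compound 2 to compound 4 cannot be read, since both ends of each are limits, so no order can be set between chloro and fluoro here, and the readable values now reduce to compound 1 against a shared limit: the limit of > 50000 nM in this assay, at which 3 of the 4 values shown sit.

As far as these compounds go, how far compound 2, compound 3 and compound 4 lie past that limit stays open, so a real difference between the two halogens could be hidden behind it. Also open, from the compounds shown here alone, is whether any other group at this site, such as a methoxy group, an amine or a nitrile, would give a readable number, and whether that number would come close to the value of compound 1 or improve on it.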